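The compounds below may be only part of what the source reports. "The series", "measured", "known", "first", "only" and "open" are said of these compounds alone.

Measured compounds:
Compound 1 `CN1C[C@H](NC(=O)OCCCCC2CCCCC2)C1=O` gives 1980 nM in an assay on HEK293 cells for inhibition of N-acylethanolamine-hydrolyzing acid amidase (Homo sapiens), read by fluorescence, with stated times of 10 min and 50 min; a lower number here means a stronger inhibitor, a higher number a weaker inhibitor.
Compound 2 `CON1C[C@@H](NC(=O)OCCCCC2CCCCC2)C1=O` gives 56 nM in this assay.
Compound 3 `CCCON1C(=O)[C@@H](NC(=O)OCCCCC2CCCCC2)[C@@H]1C` gives 133 nM in this assay.

Compound 3 stands second highest of these three numbers: compound 2 has a lower number and compound 1 a clearly higher one. Compound 4 `CCCCCCCON1C(=O)[C@@H](NC(=O)OCCCCC2CCCCC2)[C@@H]1C` differs from compound 3 by butyl in place of hydrogen on a saturated chain carbon, three bonds along the chain from an oxygen on an unsaturated carbon; in effect the propyl chain of compound 3 becomes heptyl. Within the data shown here, only one single-point step has been measured, a 35-fold lower number from compound 1 to compound 2 (1.55 log units; beyond the scatter), and it concerns swapping one group for a different kind of group on the shared core, not lengthening a chain that is already present. Compound 2 and compound 3 differ in two places at once, so their values show only that both sit well below compound 1. Among the measured compounds shown here, no measured step therefore speaks to chain length, and for compound 4 a small change or none beyond the scatter is expected in this assay, with a modest lowering as the likeliest outcome, a 1.3-fold lower number from compound 3 to compound 4 (0.12 log units; within the scatter). Compound 4 is thus estimated at 100 nM. The expected range for compound 4 runs from 35 nM to 300 nM.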

Compound 4, half-maximal inhibitory concentration: 2230 nM
Estimate against measurement, compound 4: 22-fold (1.35 log units) below; measured number above the stated range.
By their numbers in this assay, from the lowest: compound 2; then compound 3; then compounds 1 and 4 (each within the scatter of the next).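

Lengthening the propyl chain of compound 3 to the heptyl chain of compound 4 gives a 17-fold higher number from compound 3 to compound 4 (1.22 log units; beyond the scatter) in this assay. Among these compounds, this is the first measured sign that chain length at this position matters, and the added butyl, with no ring and no hydrogen-bond donors or acceptors, makes the inhibitor much weaker. No measurement at hand explains this loss of inhibition.

As far as these compounds go, with only the propyl and heptyl chains to compare, it remains open whether the number rises gradually or abruptly as the chain grows, and a butyl or pentyl chain on the same oxygen would help to settle that. From the compounds shown here alone, it is also open whether a long chain ending in an amine or a carboxylic acid would behave like the heptyl chain.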